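One trifluoromethyl removed from compound 3

The source may hold more compounds than are shown below. What is called first, only, known or untested is meant among the compounds shown, and "the series" means these compounds.

Measured so far:
compound 1 `O=C(Nc1cccc(-n2cc(-c3ccncc3)c(-c3cc(O)cc(Cl)c3)n2)c1)Nc1ccc(Cl)c(Cl)c1`: -70.3%
compound 2 `COc1cc(Cl)cc(-c2nn(-c3cccc(NC(=O)Nc4ccc(Cl)c(C(F)(F)F)c4)c3)cc2-c2ccncc2)c1`: -30%
compound 3 `COc1cc(Cl)cc(-c2nn(-c3cccc(NC(=O)Nc4cc(C(F)(F)F)cc(C(F)(F)F)c4)c3)cc2-c2ccncc2)c1`: -29.3%

In a functional assay on RXF 393 cells (Homo sapiens) for inhibition, read by sulforhodamine B assay, with a stated time of 48 h, tested at 10 uM (on this read-out higher numbers stand for a weaker effect at the one concentration tested and lower numbers for a stronger effect), compound 1 gives -70.3%, compound 2 gives -30% and compound 3 gives -29.3%. Compound 3 stands at the highest of the three numbers; compound 2 lies within the scatter of it, whereas compound 1 sits well below it, beyond the scatter. Compound 4 `COc1cc(Cl)cc(-c2nn(-c3cccc(NC(=O)Nc4cccc(C(F)(F)F)c4)c3)cc2-c2ccncc2)c1` has not yet been run in this assay. Its change from compound 3: hydrogen in place of trifluoromethyl on an aromatic carbon. Among the compounds with values here, no two measured compounds differ in a single place, so no step of this kind has been observed. The closest guide is compound 2, which carries one trifluoromethyl together with a chlorine and gives -30%, within the scatter of compound 3. On that basis the step of a number 0.7 percentage points lower from compound 3 to compound 4 (within the scatter) is expected to be small, most likely within the scatter, if anything toward a slightly lower number. Compound 4 is therefore estimated at -30%, with a range from -60% to 0%.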

Compound 4, a percentage reported as activity, at one concentration (the size of the read-out at that concentration, not a potency): 11.8%
Estimate against measurement, compound 4: 41.8 percentage points below; the whole stated range lies below it.
By their numbers in this assay, from the lowest: compound 1; then compounds 2 and 3 (each within the scatter of the next); then compound 4.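

In this assay, hydrogen in place of trifluoromethyl, on the aromatic carbon meta to a large group and meta to a trifluoromethyl group, gives a number 41.1 percentage points higher from compound 3 to compound 4 (beyond the scatter), the first single change readable in the series. Hydrogen in place of chloro on an aromatic carbon gives a number 41.8 percentage points higher from compound 2 to compound 4 (beyond the scatter), so the number moves beyond the scatter with the loss of either second group on this ring, and of the compounds shown only compound 4 gives a positive number, 11.8%. No measurement at hand bears on the reason for these steps.

On these data alone, whether a smaller group such as fluoro, or an amine or a nitrile, at this position would keep the lower number remains open. Compound 1 differs from the others in more than one place, so its hydroxy group and its pair of chloro groups cannot be read separately.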